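This account rests on a few compounds, and the source may have more. Where it says the series, first, only, none or still open, it means among the compounds named here.

Measured so far in an ADME assay on a cell-free system (plasma, Rattus norvegicus) for protein binding; on this read-out higher numbers stand for a larger free fraction and lower numbers for a smaller free fraction:
- compound 1 `N#Cc1ccc(O[C@H]2CN(S(=O)(=O)c3ccc(Cl)cc3Cl)C[C@@]2(O)CN)cc1F` gives 0.036
- compound 2 `N#Cc1ccc(O[C@H]2CN(S(=O)(=O)c3ccc(Cl)cc3Cl)C[C@]2(O)CO)cc1F` gives 0.04

Within the data shown here, compound 1 stands at the lowest of the two numbers, with compound 2 as its only neighbour; the two values lie within the usual scatter of this assay, so no order between them can be read from these figures. Compound 3 `N#Cc1ccc(O[C@H]2CN(S(=O)(=O)c3ccc(Cl)cn3)C[C@@]2(O)CN)cc1F` has not yet been measured. It differs from compound 1 in one place: 5-chloropyridin-2-yl in place of 2,4-dichlorophenyl on a sulfonyl sulfur, a change on the sulfonyl sulfur bearing the ring-bound sulfonamide nitrogen. Among the measured compounds shown here, no step between measured compounds covers such a change, so the expectation rests on compound 1 alone. A modest rise in unbound fraction is expected from compound 1 to compound 3, a step of a 1.9-fold higher number from compound 1 to compound 3 (0.29 log units; within the scatter) that may not clearly exceed the scatter. Compound 3 is accordingly estimated at 0.07 in this assay, with a range from 0.035 to 0.14.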

Compound 3, unbound fraction: 0.14
The estimate for compound 3 lay 2.0-fold (0.30 log units) below the measured number; the measured number falls inside the stated range.
By their numbers in this assay, from the lowest: compounds 1 and 2 (each within the scatter of the next); then compound 3.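

In this assay, among these compounds, the group on the sulfonyl sulfur proves able to shift the free fraction: 5-chloropyridin-2-yl in place of 2,4-dichlorophenyl gives a 3.9-fold higher number from compound 1 to compound 3 (0.59 log units; beyond the scatter) and so provides the only step read beyond the scatter. The exchange alters two things at once, going from a ring of carbon only with 2 chlorine to a ring with 1 hetero atom and 1 chlorine, and the compounds shown do not separate these two parts of the change. No measurement available here bears on the reason for the rise.

As far as these compounds go, it remains open whether an unsubstituted phenyl, a 2-chlorophenyl or a pyrimidine ring on the sulfonyl sulfur would fall nearer compound 1 or compound 3. Also open, from the compounds shown here alone, is whether the same exchange would give a comparable step on the core of compound 2.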